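The source may report more compounds than this note shows. Statements on the series, on what has been measured and on what is new or still open speak of the compounds shown alone.

Compound 1, `O=C(NCC1CCCCC1)c1cccc(/C=C2\CC(=O)N(c3ccccc3)C2=O)c1`, was examined in an ADME assay on NCM460 cells (Homo sapiens) for cytotoxicity, read by MTT assay, with a stated time of 72 h; a lower number here means a stronger inhibitor, a higher number a weaker inhibitor. For compound 1 the result is only a limit and not a number: > 100000 nM. Compound 2, `Cc1ccc(N2C(=O)C/C(=C\c3cccc(C(=O)Nc4cccc(F)c4)c3)C2=O)cc1`, was examined in this assay as well. For compound 2 the result is likewise only a limit, > 100000 nM. Both values shown therefore sit at the same point, (the limit of > 100000 nM in this assay, at which 2 of the 2 values shown sit), so compound 2 stands nowhere on a scale of numbers but at the limit, beside compound 1. Compound 3, `CCCCCN1C(=O)C/C(=C\c2cccc(C(=O)Nc3cccc(F)c3)c2)C1=O`, differs from compound 2 in one place: pentyl in place of 4-methylphenyl on an amide-type nitrogen in a ring. Going by the values given here, no step between two measured compounds exists, so no measured change anchors an expectation. Given that both known values rest at the limit, compound 3 is expected to show no step beyond the scatter in this assay, a step that the limit leaves unreadable from compound 2 to compound 3. Compound 3 is estimated at 150000 nM, within a range from 60000 nM to 400000 nM, and a limit rather than a number is again expected for compound 3.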

Compound 3, half-maximal inhibitory concentration: > 100000 nM
Compound 3 ended at the assay's limit (the forecaster's own chance of this, stated with the estimate: 80%); the middle value lies beyond the limit too.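

Compound 2 and compound 3 both give a limit rather than a number in this assay, so the swap of 4-methylphenyl for pentyl cannot be read as a step: the limit of > 100000 nM in this assay, at which 3 of the 3 values shown sit.

The compounds shown leave open how compound 1, compound 2 and compound 3 rank against one another in this assay, and which structural change, if any, would give a number there.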